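A few compounds are considered here, and "the series" means these few. Any claim that something is new, unique, unknown or untested is made for them only; others in the source may bear on it.

In an assay on CHO-K1 cells for antagonist activity at transient receptor potential cation channel subfamily V member 1 (Homo sapiens), read by FLIPR and calcium flux, with a stated time of 6 min (a lower number here means a stronger inhibitor, a higher number a weaker inhibitor), compound 1, `CC(C)(C)c1cc(CNC(=O)Nc2cccc3[nH]ncc23)n(-c2cccc(Cl)c2)n1`, gives 0.6 nM, and compound 2, `CC(C)(C)c1cc(CNC(=O)Nc2cccc3[nH]ncc23)n(-c2cccc(F)c2)n1`, gives 1.3 nM. The change from compound 1 to compound 2 is fluoro in place of chloro on an aromatic carbon, and it made a 2.2-fold higher number from compound 1 to compound 2 (0.34 log units; beyond the scatter). Compound 3, `Cn1ncc2c(NC(=O)NCc3cc(C(C)(C)C)nn3-c3ccc(Cl)cc3)cccc21`, has the highest number of the three in this assay, at 9.5 nM. The difference between the core of compound 1 and the core of compound 3 is not broken down here. Compound 4, `Cn1ncc2c(NC(=O)NCc3cc(C(C)(C)C)nn3-c3ccc(F)cc3)cccc21`, has not yet been measured; it differs from compound 3 by fluoro in place of chloro on an aromatic carbon. This is the same kind of change as that from compound 1 to compound 2, though the place is not the same: in compound 1 the halogen sits meta to a large group, whereas in compound 3 it sits para to a large group. Compound 4 is expected to show a step of a 2.1-fold higher number from compound 3 to compound 4 (0.32 log units; beyond the scatter) in this assay. That expectation rests on the earlier step of the same kind, which made a 2.2-fold higher number from compound 1 to compound 2 (0.34 log units; beyond the scatter). The estimated value for compound 4 is 20 nM, with a range from 8 nM to 50 nM.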

Compound 4, inhibition constant: 4.5 nM
Beside the measured number, compound 4's estimate is 4.4-fold (0.65 log units) above it, and the stated range ends above it.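

In this assay, the change from 4-chlorophenyl to 4-fluorophenyl gave a 2.1-fold lower number from compound 3 to compound 4 (0.32 log units; beyond the scatter), so the direction of the step seen on the core of compound 1 did not carry over to the core of compound 3, and the two steps differ: the same change on two cores in this assay, a 2.2-fold higher number (0.34 log units; beyond the scatter) from compound 1 to compound 2 and a 2.1-fold lower number (0.32 log units; beyond the scatter) from compound 3 to compound 4, 4.6-fold (0.66 log units) apart, beyond the scatter of two such steps

This does not show what reverses the step, since the two pairs differ both in their core and in where the halogen sits on the ring, and the data cannot separate these two differences. Going by these compounds alone, with only one pair on each core, no general rule for this change can be drawn from them.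

The compounds shown leave open how the same change would read with the core of compound 1 and the halogen placed as in compound 3, or with the core of compound 3 and the halogen placed as in compound 1. They also leave open how a methoxy group or a nitrile at the place of the halogen would read in this assay.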